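Hydroxyphenyl pyridines with a five-membered heteroaryl: position of the hydroxyl

A few compounds are considered here, and "the series" means these few. Any claim that something is new, unique, unknown or untested is made for them only; others in the source may bear on it.

Of the compounds shown here, three have been measured in a functional assay on HCT-15 cells (Homo sapiens) for cytotoxicity, read by CCK-8 assay (on this read-out lower numbers stand for stronger inhibition and higher numbers for weaker inhibition), and a fourth awaits its number. Compound 1 `Oc1ccc(-c2cc(-c3ccsc3)cc(-c3cccc(O)c3)n2)cc1` gives 1180 nM in this assay. Compound 3 `Oc1cccc(-c2cc(-c3ccco3)cc(-c3cccc(O)c3)n2)c1` gives 1890 nM in this assay, the higher of the two numbers, and its nearest neighbour is compound 1, whose number lies lower but within the usual scatter, so no order between the two is claimed. For compound 2 `Oc1ccc(-c2cc(-c3ccco3)cc(-c3ccccc3O)n2)cc1` this assay reports only a limit, > 50000 nM; the value is a limit of the assay and not a number, as noted in the limit of > 50000 nM in this assay, at which 1 of the 3 values shown sits.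

Compound 4 `Oc1ccc(-c2cc(-c3ccco3)cc(-c3cccc(O)c3)n2)cc1` differs from compound 3 in one place: 4-hydroxyphenyl in place of 3-hydroxyphenyl on an aromatic carbon. Going by the values given here, no measured pair in the set isolates this change on its own, so the size of the step is open. The same pair of hydroxyphenyl groups as in compound 4 is carried by compound 1, which gives 1180 nM in this assay, a number within scatter of compound 3, which argues for a small step, if any. The step from compound 3 to compound 4 is therefore expected to be small, a 1.4-fold lower number from compound 3 to compound 4 (0.13 log units; within the scatter), and not beyond the scatter. Compound 4 is estimated at 1400 nM in this assay, with a range from 500 nM to 4000 nM.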

Compound 4, half-maximal inhibitory concentration: 840 nM
Beside the measured number, compound 4's estimate is 1.7-fold (0.22 log units) above it, within the range that was stated.
By their numbers in this assay, from the lowest: compounds 4, 1 and 3 (each within the scatter of the next, the first and the last beyond it). At a limit, above all of these: compound 2.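

In this assay, going by these compounds alone, the step of a 2.3-fold lower number from compound 3 to compound 4 (0.35 log units; beyond the scatter) gives the first isolated reading at this position, on the aromatic carbon next to the ring nitrogen: with 4-hydroxyphenyl in place of 3-hydroxyphenyl, the atom counts stay the same, yet the step is modest and beyond the scatter. The value of compound 2 is a limit of the assay and not a number: the limit of > 50000 nM in this assay, at which 1 of the 4 values shown sits. Against that limit, 3-hydroxyphenyl in place of 2-hydroxyphenyl gives the large step of an at least 59-fold lower number from compound 2 to compound 4 (1.77 log units; beyond the scatter), so the hydroxyl position on this aryl group carries far more weight in this assay than the heteroaryl exchange of furan-2-yl in place of thiophen-3-yl, which is not resolved: a 1.4-fold lower number from compound 1 to compound 4 (0.15 log units; within the scatter).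

What remains open is whether the hydroxyl itself is needed, since no compound shown carries a methoxy group, an amine or a carboxylic acid in its place on either hydroxyphenyl group. The heteroaryl position is also read through a single exchange, so a thiophen-2-yl group, a furan-3-yl group or a saturated ring such as morpholine at that carbon would each be a new reading.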